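The compounds below may be only part of what the source reports. "The series", "measured", "known", "first", "only" and "open" are said of these compounds alone.

Working notes on the series. Compound 1 `COc1cc(-c2cc(/C=C/C(=O)c3ccc(N)cc3)[nH]n2)cc(OC)c1OC` and compound 2 `COc1ccc(-c2cc(/C=C/C(=O)c3ccc(OC)c(OC)c3)[nH]n2)cc1` share the same core and have both been measured in a functional assay on RXF 393 cells (Homo sapiens) for inhibition, read by sulforhodamine B assay, with a stated time of 48 h; on this read-out higher numbers stand for weaker inhibition of growth and lower numbers for stronger inhibition of growth. In this assay compound 1 gives 3240 nM. In this assay compound 2 gives 2940 nM. Within the data shown here, compound 1 carries the highest of the two numbers so far, but its gap to compound 2 lies within the scatter, so the two compounds cannot be told apart on this read-out. Compound 3 `COc1cc(-c2cc(/C=C/C(=O)c3ccc(Cl)c(Cl)c3)[nH]n2)cc(OC)c1OC` has not yet been measured. It differs from compound 1 in one place: 3,4-dichlorophenyl in place of 4-aminophenyl on a carbonyl carbon. Among the measured compounds shown here, no measured pair carries this change, so there is no step to lean on. The expected step of a 1.2-fold lower number from compound 1 to compound 3 (0.10 log units; within the scatter) is small and carries no clear direction beyond the scatter. For compound 3 the estimate in this assay is 2600 nM, within a range from 800 nM to 8500 nM.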

Compound 3, concentration for total growth inhibition: 12800 nM
Compound 3: the middle estimate sits 4.9-fold (0.69 log units) below what was measured, outside the stated range (above it).
By their numbers in this assay, from the lowest: compounds 2 and 1 (each within the scatter of the next); then compound 3.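

In this assay, among these compounds, the group on the carbonyl carbon gives the first single-place change that can be read beyond the scatter: 3,4-dichlorophenyl in place of 4-aminophenyl gives a 4.0-fold higher number from compound 1 to compound 3 (0.60 log units; beyond the scatter) and so weaker inhibition of growth. With the rest of compound 1 held fixed, this position is therefore not indifferent to the group it carries, at least for this pair. No measurement at hand accounts for the step, and this one pair cannot separate the entry of 3,4-dichlorophenyl from the departure of 4-aminophenyl.

As far as these compounds go, it remains open whether an unsubstituted phenyl or a 4-chlorophenyl on the same carbonyl carbon would stand with compound 1 or with compound 3. From the compounds shown here alone, it also remains open whether the same change would give a similar step on the core of compound 2.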